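The source may report more compounds than this note shows. Statements on the series, on what has been measured and on what is new or still open speak of the compounds shown alone.

Measured compounds:
compound 1 `COc1ccc(C2=NN(C(=O)c3cccnc3)C(c3cn(C)c4ccc(Br)cc34)C2)cc1`: 540 nM
compound 2 `COc1cc(C2=NN(C(=O)c3cccnc3)C(c3cn(C)c4ccc(Br)cc34)C2)cc(OC)c1OC`: a limit, > 10000 nM
compound 3 `COc1ccc(C2=NN(C(=O)c3ccc(OC)nc3)C(c3cn(C)c4ccc(OC)cc34)C2)cc1`: 230 nM

In a functional assay on HepG2 cells (Homo sapiens) for inhibition, read by MTT assay, with a stated time of 48 h (on this read-out higher numbers stand for weaker inhibition of growth and lower numbers for stronger inhibition of growth), compound 1 gives 540 nM. Compound 2 reaches only a limit of this assay, > 10000 nM. The change from compound 1 to compound 2 is 3,4,5-trimethoxyphenyl in place of 4-methoxyphenyl on a carbon with a double bond to nitrogen; it brings an at least 18-fold higher number from compound 1 to compound 2 (1.26 log units; beyond the scatter), the value running to the limit of > 10000 nM in this assay, at which 1 of the 3 values shown sits. Compound 3 gives 230 nM in this assay, a number below that of compound 1; how its core differs from the core of compound 1 is not broken down here.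

Compound 4 `COc1ccc2c(c1)c(C1CC(c3cc(OC)c(OC)c(OC)c3)=NN1C(=O)c1ccc(OC)nc1)cn2C` is not yet measured in this assay. It differs from compound 3 by 3,4,5-trimethoxyphenyl in place of 4-methoxyphenyl on a carbon with a double bond to nitrogen, the same kind of change as that from compound 1 to compound 2, though around the place a (6-methoxypyridin-3-yl)carbonyl group stands where compound 1 carries a (pyridin-3-yl)carbonyl group. Given an at least 18-fold higher number from compound 1 to compound 2 (1.26 log units; beyond the scatter) from the same kind of change, compound 4 is expected to show a rise of about a 22-fold higher number from compound 3 to compound 4 (1.34 log units; beyond the scatter). Compound 4 is estimated at 5000 nM, between 1500 nM and 20000 nM, with a fair chance that only a limit is reported.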

Compound 4, concentration for 50% growth inhibition: > 10000 nM
Compound 4 was reported as a limit (the forecaster's own chance of this, stated with the estimate: 45%); middle value at least 2.0-fold (0.30 log units) away from the limit.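

In this assay, 3,4,5-trimethoxyphenyl in place of 4-methoxyphenyl on a carbon with a double bond to nitrogen again weakens growth inhibition, with an at least 43-fold higher number from compound 3 to compound 4 (1.63 log units; beyond the scatter), so the direction of the change carries over from the core of compound 1 to the core of compound 3. Compound 4 reaches only a limit of the assay, > 10000 nM, and compound 2 is also a limit, so neither step has a fixed size and no difference between the two cores can be claimed: the same change on two cores in this assay, an at least 18-fold higher number (1.26 log units; beyond the scatter) from compound 1 to compound 2 and an at least 43-fold higher number (1.63 log units; beyond the scatter) from compound 3 to compound 4; the limit leaves it open whether they differ. The result shows the same direction on two cores only, and neither compound with the 3,4,5-trimethoxyphenyl group gives an actual number: the limit of > 10000 nM in this assay, at which 2 of the 4 values shown sit.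

The compounds shown leave open whether a dimethoxyphenyl, hydroxyphenyl or fluorophenyl group at this place would keep growth inhibition or lose it as well. They also leave open how far the remaining groups on the core of compound 3 can be varied while the 4-methoxyphenyl group stays in place.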